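The source may report more compounds than this note shows. Statements on the series, on what has been measured and on what is new or still open speak of the compounds shown alone.

Working notes on the series. Compound 1 `CC1=C(C(=O)Nc2ccc([N+](=O)[O-])cc2)C(c2ccc(Br)cc2)N=C(SCc2ccccc2)N1` is the reference point of the set; in a functional assay on the whole organism (artery, strain albino) with Rattus norvegicus as the target, with a stated time of 720 min, at a dose of 10 mg/kg by the oral route (on this read-out higher numbers stand for more inhibition at the one dose given (going by the name of the read-out) and lower numbers for less inhibition), compound 1 gives 21.1%. Compound 2 `CC1=C(C(=O)Nc2ccc([N+](=O)[O-])cc2)C(c2ccc(Br)cc2)N=C(SCc2ccccc2Cl)N1` carries chloro in place of hydrogen on an aromatic carbon; in this assay compound 2 gives 6.7%, which is a number 14.4 percentage points lower from compound 1 to compound 2 (beyond the scatter). Compound 3 `CC1=C(C(=O)Nc2ccc([N+](=O)[O-])cc2)C(c2cccc([N+](=O)[O-])c2)N=C(SCc2ccccc2)N1` carries 3-nitrophenyl in place of 4-bromophenyl on a saturated ring carbon; in this assay compound 3 gives 17.5%, which is a number 3.6 percentage points lower from compound 1 to compound 3 (within the scatter). Compound 3 therefore stands second highest of the three numbers, within the scatter of compound 1 and separated from compound 2 by a gap beyond the scatter.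

Compound 4 `CC1=C(C(=O)Nc2ccc([N+](=O)[O-])cc2)C(c2cccc([N+](=O)[O-])c2)N=C(SCc2ccccc2Cl)N1` differs from compound 3 by chloro in place of hydrogen on an aromatic carbon. For the measured compounds named here, one measured step bears on this change directly: a number 14.4 percentage points lower from compound 1 to compound 2 (beyond the scatter), a modest fall beyond the scatter. The other step, a number 3.6 percentage points lower from compound 1 to compound 3 (within the scatter), concerns a different part of the structure and stayed within the scatter, so it gives no reason to expect the chloro step to behave differently on the 3-nitrophenyl background. A fall of similar size is therefore expected in this assay for compound 4, namely a number 12.5 percentage points lower from compound 3 to compound 4 (beyond the scatter). Compound 4 is estimated at 5%, with a range from -4% to 14%.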

Compound 4, a percentage reported as inhibition, in the whole organism at one dose (the size of the read-out at that dose, not a potency): 11.3%
The estimate for compound 4 lay 6.3 percentage points below the measured number, within the range that was stated.
By their numbers in this assay, from the lowest: compounds 2, 4, 3 and 1 (each within the scatter of the next, the first and the last beyond it).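

On the 3-nitrophenyl background, chloro in place of hydrogen gives in this assay a number 6.2 percentage points lower from compound 3 to compound 4 (within the scatter), so the step that lay beyond the scatter on the 4-bromophenyl background does not do so here. Even so, the data do not show that the background alters the chloro step, since its two readings differ by no more than two such steps can scatter: the same change on two cores in this assay, a number 14.4 percentage points lower (beyond the scatter) from compound 1 to compound 2 and a number 6.2 percentage points lower (within the scatter) from compound 3 to compound 4, 8.2 percentage points apart, within the scatter of two such steps. Read the other way, 3-nitrophenyl in place of 4-bromophenyl with the 2-chlorobenzyl group present gives a number 4.6 percentage points higher from compound 2 to compound 4 (within the scatter), which shows that this exchange stays within the scatter on both sulfanyl groups: the same change on two cores in this assay, a number 3.6 percentage points lower (within the scatter) from compound 1 to compound 3 and a number 4.6 percentage points higher (within the scatter) from compound 2 to compound 4, 8.2 percentage points apart, within the scatter of two such steps.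

Chloro is the only group read here on the six-membered aromatic ring of the benzyl group, and only ortho to a large group, so it remains open whether a methoxy group, an amine or a carboxylic acid at that place would give a step of similar size. With every number taken at one oral dose, the set also leaves open how these compounds would compare across a range of doses.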